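Notes on the aryl group at the ring nitrogen

The source may hold more compounds than are shown below. What is called first, only, known or untested is meant among the compounds shown, and "the series" means these compounds.

Measured so far in an assay on CHO cells for antagonist activity at lysophosphatidic acid receptor 5 (Rattus norvegicus), read by cAMP accumulation, with a stated time of 30 min; a higher number here means a weaker inhibitor, a lower number a stronger inhibitor:
compound 1, `CCN1CCc2ccc(-n3cc(C(=O)N4CCC(F)CC4)c4cc(OC)c(OC)cc4c3=O)cc21`, gives 120 nM.
compound 2, `CCc1ccc(-n2cc(C(=O)N3CCCCCC3)c3cc(OC)c(OC)cc3c2=O)cc1`, gives 570 nM.
compound 3, `COc1cc2c(C(=O)N3CCCCCC3)cn(C(C)C)c(=O)c2cc1OC`, gives only a limit, > 30000 nM.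

Within the data shown here, compound 2 stands highest of the two numbers in this assay; compound 1 gives a lower number, beyond the scatter, but compound 1 differs from compound 2 at two places and no single step covers that pair. Compound 3 sits at the assay limit (the limit of > 30000 nM in this assay, at which 1 of the 3 values shown sits). Among the measured compounds shown here, the one measured step, an at least 52-fold higher number from compound 2 to compound 3 (1.72 log units; beyond the scatter), shows that exchanging the aryl group on the aromatic nitrogen for isopropyl removes almost all inhibition. Compound 4, `CCN1CCc2ccc(-n3cc(C(=O)N4CCCCCC4)c4cc(OC)c(OC)cc4c3=O)cc21`, is not yet measured; it differs from compound 2 by 1-ethyl-2,3-dihydro-1H-indol-6-yl in place of 4-ethylphenyl on an aromatic nitrogen. An aryl group stays on that nitrogen, so the large loss seen with the isopropyl compound is not expected here. A step of a 2.9-fold lower number from compound 2 to compound 4 (0.45 log units; beyond the scatter) toward a lower number is expected, as compound 1 with the same indoline group gives 120 nM. Compound 4 is therefore estimated at 200 nM, within 60 nM to 700 nM.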

Compound 4, half-maximal inhibitory concentration: 110 nM
Beside the measured number, compound 4's estimate is 1.8-fold (0.26 log units) above it; the range from low to high includes it.
By their numbers in this assay, from the lowest: compounds 4 and 1 (each within the scatter of the next); then compound 2. At a limit, above all of these: compound 3.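

With the azepan-1-yl amide held constant, 1-ethyl-2,3-dihydro-1H-indol-6-yl in place of 4-ethylphenyl in this assay gives a 5.2-fold lower number from compound 2 to compound 4 (0.71 log units; beyond the scatter), so the advantage of this aryl group now rests on a single-place comparison rather than on compound 1, which differed at two places. With that aryl group in place, the two amides do not separate: a 1.1-fold lower number from compound 1 to compound 4 (0.04 log units; within the scatter). The change from isopropyl, an at least 270-fold lower number from compound 3 to compound 4 (2.43 log units; beyond the scatter), rests on a value that is only a limit: the limit of > 30000 nM in this assay, at which 1 of the 4 values shown sits.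

On these data alone, it remains open whether the ring nitrogen of the 1-ethyl-2,3-dihydro-1H-indol-6-yl group is needed, which a dimethylaminophenyl group on the same aromatic nitrogen would test. The ethyl on that ring nitrogen is also untested against methyl, propyl or acetyl.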